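The compounds below may be only part of what the source reports. "The series", "measured", "known", "first", "only" and "open" are said of these compounds alone.

Working notes on side chains carried on an amide-type nitrogen of the shared core, read in a functional assay on MCF7 cells (Homo sapiens) for cytotoxicity, read by MTT assay, with a stated time of 72 h; a lower number here means a stronger inhibitor, a higher number a weaker inhibitor. Compound 1 `COc1ncc(-c2ccc3nc(NC(=O)NC4CC4)nn3c2)cc1NS(=O)(=O)c1ccc(F)cc1` gives 300 nM and compound 2 `COc1ncc(-c2ccc3nc(NC(=O)NCCN4CCCCC4)nn3c2)cc1NS(=O)(=O)c1ccc(F)cc1` gives 200 nM, with a 1.5-fold lower number from compound 1 to compound 2 (0.18 log units; within the scatter). Compound 3 `COc1ncc(-c2ccc3nc(NC(=O)NCC(=O)N4CCCC4)nn3c2)cc1NS(=O)(=O)c1ccc(F)cc1` gives 2130 nM, the highest number of the three and the weakest so far, with a 7.1-fold higher number from compound 1 to compound 3 (0.85 log units; beyond the scatter) and an 11-fold higher number from compound 2 to compound 3 (1.03 log units; beyond the scatter).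

The next structure is compound 4 `COc1ncc(-c2ccc3nc(NC(=O)NCC(=O)N4CCOCC4)nn3c2)cc1NS(=O)(=O)c1ccc(F)cc1`, with morpholin-4-yl in place of pyrrolidin-1-yl on a carbonyl carbon. Among the measured compounds shown here, no measured step varies this ring while keeping the carbonyl, so the evidence is indirect. The two steps into compound 3 are both large enough to show that the side chain matters, but each replaces far more of the side chain than this change does. Compound 4 keeps the carbonyl and chain of compound 3 2130 nM, so no step beyond the scatter is expected in this assay. The expected change is a 1.2-fold higher number from compound 3 to compound 4 (0.07 log units; within the scatter). For compound 4 the estimated value is 2500 nM, with an expected range of 900 nM to 7000 nM.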

Compound 4, half-maximal inhibitory concentration: 630 nM
For compound 4 the middle estimate is 4.0-fold (0.60 log units) above the measured one, and the stated range ends above it.
By their numbers in this assay, from the lowest: compounds 2 and 1 (each within the scatter of the next); then compound 4; then compound 3.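

In this assay, the ring on the carbonyl carbon counts on its own: with the chain and carbonyl held constant, morpholin-4-yl in place of pyrrolidin-1-yl gives a 3.4-fold lower number from compound 3 to compound 4 (0.53 log units; beyond the scatter). Compound 4 keeps the carbonyl-bearing chain of compound 3 and still gives a lower number. A gap to the other two side chains remains, with a 3.2-fold higher number from compound 2 to compound 4 (0.50 log units; beyond the scatter) and a 2.1-fold higher number from compound 1 to compound 4 (0.32 log units; beyond the scatter). Nothing measured here bears on why this ring change moves the number.

Still open, going by these compounds, is whether the ring oxygen or the six-membered ring size carries the step, which a piperidin-1-yl ring on the same carbonyl carbon would separate. Also open, on these data alone, is what the carbonyl contributes with this ring, which a 2-(morpholin-4-yl)ethyl chain on the amide-type nitrogen would test against compound 2.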